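Furanylmethyl to 4-methylphenyl exchange across two cores

A few compounds are considered here, and "the series" means these few. Any claim that something is new, unique, unknown or untested is made for them only; others in the source may bear on it.

Three compounds of this set have been run in a functional assay on MCF7 cells (Homo sapiens) for inhibition, read by CCK-8 assay, with a stated time of 48 h; on this read-out lower numbers stand for stronger inhibition of growth and higher numbers for weaker inhibition of growth. Compound 1 `Cc1ccc(Nc2ncc(Cl)c(Nc3ccccc3C)n2)cc1` returns a limit rather than a number, > 100000 nM. Compound 2 `Cc1ccccc1Nc1nc(NCc2ccco2)ncc1Cl` likewise returns only a limit, > 100000 nM. Within the data shown here, compound 3 `CN1CCN(c2ccc(Nc3ncc(Cl)c(NCc4ccco4)n3)nc2)CC1` is the one member with a number, giving 21300 nM in this assay; the other two values sit at the limit of > 100000 nM in this assay, at which 2 of the 3 values shown sit.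

Compound 2 and compound 1 differ in one place: 4-methylphenyl in place of (furan-2-yl)methyl on a nitrogen on an aromatic ring. The size of that step, a step that the two limits leave unreadable from compound 2 to compound 1, cannot be read because the limit of > 100000 nM in this assay, at which 2 of the 3 values shown sit, holds both of its ends. The difference between the cores of compound 3 and compound 2 is not broken down here.

Compound 4 `Cc1ccc(Nc2nc(Nc3ccc(N4CCN(C)CC4)cn3)ncc2Cl)cc1` stands to compound 3 as compound 1 stands to compound 2: 4-methylphenyl in place of (furan-2-yl)methyl on a nitrogen on an aromatic ring. The surroundings of the changed nitrogen read the same word for word in both pairs, so this is the same change, occurring twice among the compounds shown. For the step from compound 3 to compound 4 in this assay the earlier occurrence offers no size, so the expectation rests only on compound 3 carrying a number and on compound 1, which bears the entering 4-methylphenyl group, sitting at a limit. The step expected is a 2.1-fold higher number from compound 3 to compound 4 (0.32 log units; beyond the scatter), a drift toward weaker inhibition rather than a gain. Compound 4 is accordingly expected at about 45000 nM, with the estimate spanning 12000 nM to 150000 nM, and a fair chance that only a limit is returned.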

Compound 4, concentration for 50% growth inhibition: 11400 nM
Estimate against measurement, compound 4: 3.9-fold (0.60 log units) above; measured number outside the range, below it.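

On the one core where both ends carry numbers, putting 4-methylphenyl in place of (furan-2-yl)methyl on the nitrogen gives, in this assay, a 1.9-fold lower number from compound 3 to compound 4 (0.27 log units; within the scatter), so on this core the two groups cannot be told apart on this read-out. The same change on the other core cannot be read, because compound 2 and compound 1 both return only a limit: the limit of > 100000 nM in this assay, at which 2 of the 4 values shown sit. The series therefore offers a single sized occurrence of this change, which shows that it is tolerated without a step beyond the scatter on one core, but it does not show that the step carries over to the other core, nor that the two cores respond alike.

The compounds shown leave open whether any group on this nitrogen would move the number beyond the scatter, for instance a longer chain than (furan-2-yl)methyl ending in an amine, or a carboxylic acid in place of the methyl of 4-methylphenyl. They also leave open whether such a group would bring the core of compound 1 off its limit, so that the change could be sized on a second core.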